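The source may report more compounds than this note shows. Statements on the series, on what has been measured and on what is new or still open speak of the compounds shown alone.

Of the compounds shown here, three built on a shared core have been measured in a functional assay on SK-OV-3 cells (Homo sapiens) for cytotoxicity, read by MTT assay, with a stated time of 48 h; a higher number here means a weaker inhibitor, a lower number a stronger inhibitor. Compound 1 `O=C(/C=C/c1ccc2c(c1)B(O)OC2)c1ccc(F)cc1` gives 1400 nM in this assay. Compound 2 `O=C(/C=C/c1ccc2c(c1)B(O)OC2)c1ccc(Cl)cc1` gives 3700 nM, and compound 3 `O=C(/C=C/c1ccc2c(c1)B(O)OC2)c1ccc(C(F)(F)F)cc1` gives 3700 nM. Compound 2 thus stands level with compound 3, and the two together hold the highest number of the three; its furthest neighbour is compound 1, reached through the step of a 2.6-fold higher number from compound 1 to compound 2 (0.42 log units; beyond the scatter). The swap of the fluoro for trifluoromethyl gave a 2.6-fold higher number from compound 1 to compound 3 (0.42 log units; beyond the scatter), and from compound 2 to compound 3 the result was no change at the digits printed from compound 2 to compound 3 (within the scatter).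

Compound 4 `O=C(/C=C/c1ccc2c(c1)B(O)OC2)c1ccc(Cl)c(Cl)c1` differs from compound 2 by chloro in place of hydrogen on an aromatic carbon. Among the compounds with values here, none of the measured steps adds a group to a position that was bare before; each of them only exchanges the group already present, so they bear on this change only indirectly. What they do show is that the change among chloro and trifluoromethyl left this assay untouched, and that even the fluoro-to-chloro exchange moved it only modestly. Compound 4 is therefore expected to land close to compound 2, with a step of a 1.2-fold higher number from compound 2 to compound 4 (0.09 log units; within the scatter), and its estimated value is 4500 nM, likely falling from 2000 nM to 10000 nM.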

Compound 4, half-maximal inhibitory concentration: 1800 nM
Compound 4: the middle estimate sits 2.5-fold (0.40 log units) above what was measured; measured number below the stated range.
By their numbers in this assay, from the lowest: compounds 1 and 4 (each within the scatter of the next); then compounds 2 and 3 (each within the scatter of the next).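

Within the data shown here, the aromatic carbon ortho to a chloro group and meta to a large group was bare in compounds 1 to 3, so the earlier steps said nothing about filling it; compound 4 shows that a chloro placed there does not cost activity in this assay, and the change gives a 2.1-fold lower number from compound 2 to compound 4 (0.31 log units; beyond the scatter), a modest move toward stronger inhibition. This is also the first step shown that starts from compound 2 and lowers the number, whereas the exchange of chloro for trifluoromethyl at the existing site left the value unchanged within the scatter, so this newly filled position responds where that exchange did not. Nothing at hand accounts for this shift, and the finding rests on a single added group in a single pair of compounds.

The compounds shown leave open whether the same addition would lower the number when the neighbouring group is the fluoro of compound 1 or the trifluoromethyl of compound 3. They also leave open whether a different group at this position, such as a methoxy group, an amine or a carboxylic acid, would act as the chloro does.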